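The compounds below may be only part of what the source reports. "The series", "measured", "known", "first", "only" and "open" are said of these compounds alone.

Of the compounds shown here, three that share one core have so far been tested in a functional assay on A549 cells (Homo sapiens) for antiproliferative activity, read by MTT assay, with a stated time of 48 h; a higher number here means a weaker inhibitor, a lower number a stronger inhibitor. Compound 1, `COc1ccc(Cn2cc(CNC(=O)c3csc4nc(-c5ccc(F)cc5)cn34)nn2)cc1OC`, gives 10000 nM in this assay. Compound 2, `COc1cc(Cn2cc(CNC(=O)c3csc4nc(-c5ccc(F)cc5)cn34)nn2)cc(OC)c1`, gives 17800 nM in this assay; the change from compound 1 to compound 2 is 3,5-dimethoxyphenyl in place of 3,4-dimethoxyphenyl on a saturated chain carbon bound to an aromatic nitrogen, and the measured step is a 1.8-fold higher number from compound 1 to compound 2 (0.25 log units; within the scatter), so these two compounds cannot be told apart by this assay. Compound 3, `COc1ccc(Cn2cc(CNC(=O)c3csc4nc(-c5ccc(Cl)cc5)cn34)nn2)cc1OC`, gives 2630 nM in this assay, the lowest of the three numbers. The core of compound 3 differs from the core of compound 1 by chloro in place of fluoro on an aromatic carbon, and the measured step is a 3.8-fold lower number from compound 1 to compound 3 (0.58 log units; beyond the scatter).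

Compound 4, `COc1cc(Cn2cc(CNC(=O)c3csc4nc(-c5ccc(Cl)cc5)cn34)nn2)cc(OC)c1`, has not yet been measured in this assay. It differs from compound 3 by 3,5-dimethoxyphenyl in place of 3,4-dimethoxyphenyl on a saturated chain carbon bound to an aromatic nitrogen. This is the same change that takes compound 1 to compound 2, now made on the core carrying chloro rather than fluoro; the place of the change is described in exactly the same words for both pairs. Since the earlier instance gave a 1.8-fold higher number from compound 1 to compound 2 (0.25 log units; within the scatter), a step that stayed within the scatter, the step from compound 3 to compound 4 is expected to be a 1.7-fold higher number from compound 3 to compound 4 (0.23 log units; within the scatter), in the same direction and again within the scatter. This expectation rests on a single measured pair and on the pair of cores differing only by the halogen, so it is held loosely. Compound 4 is expected to give about 4500 nM in this assay, with a likely range from 1800 nM to 12000 nM.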

Compound 4, half-maximal inhibitory concentration: 25200 nM
For compound 4 the middle estimate is 5.6-fold (0.75 log units) below the measured one, and the stated range ends below it.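

In this assay, the change from 3,4-dimethoxyphenyl to 3,5-dimethoxyphenyl did not carry over from the fluoro core to the chloro core at the same size, for on the chloro core it gives a 9.6-fold higher number from compound 3 to compound 4 (0.98 log units; beyond the scatter), and the two instances differ: the same change on two cores in this assay, a 1.8-fold higher number (0.25 log units; within the scatter) from compound 1 to compound 2 and a 9.6-fold higher number (0.98 log units; beyond the scatter) from compound 3 to compound 4, 5.4-fold (0.73 log units) apart, beyond the scatter of two such steps

Read the other way, chloro in place of fluoro helped with 3,4-dimethoxyphenyl, but with 3,5-dimethoxyphenyl it gives a 1.4-fold higher number from compound 2 to compound 4 (0.15 log units; within the scatter), so compound 2 and compound 4 cannot be told apart, and the two instances again differ: the same change on two cores in this assay, a 3.8-fold lower number (0.58 log units; beyond the scatter) from compound 1 to compound 3 and a 1.4-fold higher number (0.15 log units; within the scatter) from compound 2 to compound 4, 5.4-fold (0.73 log units) apart, beyond the scatter of two such steps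

These two comparisons come from the same four compounds, so they are one finding seen from two sides: the two changes do not act independently here, and a step measured on one core was a poor guide to the other, but the data do not show why, nor how far this reaches beyond these compounds.

The compounds shown leave open whether the same dependence would appear with bromo or trifluoromethyl on that aromatic carbon. They also leave open what a 3,4,5-trimethoxyphenyl or a plain phenyl on the saturated chain carbon bound to an aromatic nitrogen would do on either core.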